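Swapping hydroxy for amino on one chain carbon

This account rests on a few compounds, and the source may have more. Where it says the series, first, only, none or still open, it means among the compounds named here.

Measured in a functional assay on HCT-8 cells (Homo sapiens) for antiproliferative activity, read by MTT assay, with a stated time of 48 h; a higher number here means a weaker inhibitor, a lower number a stronger inhibitor:
- compound 1 `COc1ccc(C(=O)c2ccc3c(c2)C=CC(C)(C)O3)c(NC(=O)CBr)c1`: 3260 nM
- compound 2 `COc1ccc(C(=O)c2ccc3c(c2)C=CC(C)(C)O3)c(NC(=O)CO)c1`: 250 nM

Of these two, compound 2 has the lower number, so it is the stronger inhibitor. Compound 3 `COc1ccc(C(=O)c2ccc3c(c2)C=CC(C)(C)O3)c(NC(=O)CN)c1` carries amino in place of hydroxy on a saturated chain carbon bound to a carbonyl carbon. Within the data shown here, only one measured step bears on this carbon: a 13-fold lower number from compound 1 to compound 2 (1.12 log units; beyond the scatter), a large change. Among the measured compounds shown here, it shows that the group there can matter, but no measured compound carries amino. Hydroxy and amino also match in what is counted, so only a small change is expected, with no firm direction. The expected step is a 1.2-fold higher number from compound 2 to compound 3 (0.08 log units; within the scatter), within the scatter. For compound 3 the estimated value is 300 nM, with an expected range of 70 nM to 1200 nM.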

Compound 3, half-maximal inhibitory concentration: 490 nM
Compound 3: middle estimate off by 1.6-fold (0.21 log units), on the low side; the range from low to high includes it.
By their numbers in this assay, from the lowest: compounds 2 and 3 (each within the scatter of the next); then compound 1.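

In this assay, a 2.0-fold higher number from compound 2 to compound 3 (0.29 log units; within the scatter) lies within the scatter, so hydroxy and amino cannot be told apart at this carbon. Leaving bromo for amino gives a 6.7-fold lower number from compound 1 to compound 3 (0.82 log units; beyond the scatter) and is a second step beyond the scatter, so the lower number seen earlier is not special to hydroxy. Nothing available here explains why these groups differ from bromo. Still open, as far as these compounds go, is how a dimethylamino or a methoxy group on this carbon would compare, and whether a longer chain ending in amino would keep the number this low.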